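Removing the methyl from the methoxy group

The source may report more compounds than this note shows. Statements on the series, on what has been measured and on what is new or still open speak of the compounds shown alone.

Compound 3 `COc1ccc([C@@]2(CO)NC[C@H](O)[C@H]2O)cc1` stands second highest of the three numbers in an assay on isolated protein for inhibition of lysosomal alpha-glucosidase (Rattus norvegicus), read by colorimetric assay (a higher number here means a weaker inhibitor, a lower number a stronger inhibitor), giving 2100 nM. Compound 2 `OC[C@]1(c2ccccc2)NC[C@H](O)[C@H]1O` gives 190 nM, while compound 1 `OC[C@]1(c2ccc(F)cc2)NC[C@H](O)[C@H]1O` gives 101000 nM. The measured steps of an 11-fold higher number from compound 2 to compound 3 (1.04 log units; beyond the scatter) and a 48-fold lower number from compound 1 to compound 3 (1.68 log units; beyond the scatter) frame where compound 3 sits.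

Compound 4 `OC[C@]1(c2ccc(O)cc2)NC[C@H](O)[C@H]1O` differs from compound 3 by hydrogen in place of methyl on an oxygen on an aromatic ring. Among the measured compounds shown here, none of the measured steps removes a methyl from an aromatic oxygen; the steps that bear on it are an 11-fold higher number from compound 2 to compound 3 (1.04 log units; beyond the scatter), which introduced the methoxy group, and a 530-fold lower number from compound 1 to compound 2 (2.73 log units; beyond the scatter). Because an 11-fold higher number from compound 2 to compound 3 (1.04 log units; beyond the scatter) introduced the methoxy group whose oxygen remains while only the methyl leaves, the step is expected to run partly back toward compound 2, a 2.1-fold lower number from compound 3 to compound 4 (0.32 log units; beyond the scatter). Compound 4 is therefore estimated at 1000 nM, within 200 nM to 5000 nM.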

Compound 4, half-maximal inhibitory concentration: 2600 nM
Compound 4: the middle estimate sits 2.6-fold (0.41 log units) below what was measured; the range from low to high includes it.
By their numbers in this assay, from the lowest: compound 2; then compounds 3 and 4 (each within the scatter of the next); then compound 1.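

In this assay, going from methoxy to hydroxy on this aromatic ring gives a 1.2-fold higher number from compound 3 to compound 4 (0.09 log units; within the scatter) and so shows no readable effect of the methyl alone. The oxygen stays on the ring, and the larger gaps persist, with a 14-fold higher number from compound 2 to compound 4 (1.14 log units; beyond the scatter) and a 39-fold lower number from compound 1 to compound 4 (1.59 log units; beyond the scatter) both beyond the scatter. No measurement shown here explains this result.

From the compounds shown here alone, it remains open whether an amine or a carboxylic acid on the same aromatic carbon would fall near the oxygen-bearing compounds. Going by these compounds, a longer chain on the oxygen is equally open.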